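Swapping the anilino ring for an isopentyl chain

A few compounds are considered here, and "the series" means these few. Any claim that something is new, unique, unknown or untested is made for them only; others in the source may bear on it.

Measured compounds:
- compound 1 `CC(=O)NC[C@H]1CN(c2ccc(OC[C@H](O)CNc3ccccc3)c(F)c2)C(=O)O1`: 0.59
- compound 2 `CC(=O)NC[C@H]1CN(c2ccc(OC[C@H](O)CNc3cccnc3)c(F)c2)C(=O)O1`: -0.18
- compound 3 `CC(=O)NC[C@H]1CN(c2ccc(OC[C@@H](O)CNc3ccncc3)c(F)c2)C(=O)O1`: -0.04

In a physicochemical assay for lipophilicity, read by HPLC (a higher number here means a more lipophilic compound, a lower number a more polar compound), compound 1 stands highest of the three; compound 2 and compound 3 both lie lower, by a number 0.77 log units lower from compound 1 to compound 2 (beyond the scatter) and a number 0.63 log units lower from compound 1 to compound 3 (beyond the scatter). Between them the gap is a number 0.14 log units higher from compound 2 to compound 3 (within the scatter).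

Compound 4 `CC(=O)NC[C@H]1CN(c2ccc(OC[C@@H](O)CNCCC(C)C)c(F)c2)C(=O)O1` has not yet been measured. It differs from compound 1 as follows: 1-hydroxy-2-(isopentylamino)ethyl in place of 2-anilino-1-hydroxyethyl on a saturated chain carbon bound to an oxygen on an aromatic ring. Neither measured step bears directly on this change, since both exchange the phenyl ring for another ring rather than for a chain; they show only that altering this part shifts the number by modest amounts. The estimate for compound 4 is therefore tentative: a drop of a number 0.89 log units lower from compound 1 to compound 4 (beyond the scatter) is expected, giving -0.3 with a range from -1.3 to 0.5.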

Compound 4, partition coefficient: 1.17
Compound 4: middle estimate off by 1.47 log units, on the low side, and the stated range ends below it.
By their numbers in this assay, from the lowest: compounds 2 and 3 (each within the scatter of the next); then compound 1; then compound 4.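

In this assay this position can move the number up as well as down: the isopentyl chain gives a number 0.58 log units higher from compound 1 to compound 4 (beyond the scatter) and so reverses the direction seen with the pyridine rings. Against those rings, the chain gives larger steps, a number 1.21 log units higher from compound 3 to compound 4 (beyond the scatter) and a number 1.35 log units higher from compound 2 to compound 4 (beyond the scatter), so whether a ring or a chain sits on this amine nitrogen matters more than which pyridine ring is used.

Still open, as far as these compounds go, is whether an ethyl group, a longer chain or a cyclohexyl ring would land nearer compound 1 or compound 4. No measurement shown here explains the higher number of the isopentyl chain.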